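A few compounds are considered here, and "the series" means these few. Any claim that something is new, unique, unknown or untested is made for them only; others in the source may bear on it.

Measured so far in a functional assay on A549 cells (Homo sapiens) for inhibition, read by CCK-8 assay, with a stated time of 72 h, tested at 1 uM; on this read-out lower numbers stand for less inhibition of growth and higher numbers for more inhibition of growth at the one concentration tested:
- compound 1 `CN(C)C(=O)c1cc2cnc(Nc3ccc(NC(=O)C4(C(=O)Nc5cccc(F)c5)CC4)cc3)nc2n1C1CCCC1`: 33.2%
- compound 2 `CN(C)C(=O)c1cc2cnc(Nc3ccc(NC(=O)C4(C(=O)Nc5ccc(Cl)c(C(F)(F)F)c5)CC4)cc3)nc2n1C1CCCC1`: 1.1%

Of these two, compound 2 stands lowest at 1.1%. Compound 3 `CN(C)C(=O)c1cc2cnc(Nc3ccc(NC(=O)C4(C(=O)Nc5cccc(C#N)c5)CC4)cc3)nc2n1C1CCCC1` carries 3-cyanophenyl in place of 4-chloro-3-(trifluoromethyl)phenyl on an amide-type nitrogen. Going by the values given here, one measured step bears on this change: putting 4-chloro-3-(trifluoromethyl)phenyl in place of 3-fluorophenyl at that nitrogen gave a number 32.1 percentage points lower from compound 1 to compound 2 (beyond the scatter), a large drop. Compound 3 gives up that same group, so a large rise is expected in this assay, somewhat smaller than that drop, as a number 23.9 percentage points higher from compound 2 to compound 3 (beyond the scatter). The estimated value for compound 3 is 25%, within a range of 8% to 45%.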

Compound 3, percent growth inhibition at one concentration: 70.8%
For compound 3 the middle estimate is 45.8 percentage points below the measured one; measured number above the stated range.
By their numbers in this assay, from the lowest: compound 2; then compound 1; then compound 3.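

In this assay, the group on this amide-type nitrogen can do more than lower the number: 3-cyanophenyl in place of 4-chloro-3-(trifluoromethyl)phenyl gives a number 69.7 percentage points higher from compound 2 to compound 3 (beyond the scatter) and so recovers far more than the earlier drop. Compound 3 also passes the 3-fluorophenyl compound, as cyano in place of fluoro on an aromatic carbon gives a number 37.6 percentage points higher from compound 1 to compound 3 (beyond the scatter) with the rest of the molecule unchanged. Nothing available explains either rise.

Still open, going by these compounds, is whether an amine or a carboxylic acid in place of the cyano group would keep this level of growth inhibition.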